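Swapping Bromo for Methyl in an Oxime Ether Series

A few compounds are considered here, and "the series" means these few. Any claim that something is new, unique, unknown or untested is made for them only; others in the source may bear on it.

In a functional assay on SMMC-7721 cells (Homo sapiens) for inhibition, read by MTT assay, with a stated time of 72 h, tested at 25 uM (on this read-out lower numbers stand for less inhibition and higher numbers for more inhibition at the one concentration tested (going by the name of the read-out)), compound 1 `CCc1nn(C)c(CO/N=C/c2c(C)nn(C)c2Oc2ccc(Br)cc2)c1Cl` gives < 80%, which is a limit of the assay rather than a number. Compound 2 `CCc1nn(C)c(CO/N=C/c2c(C)nn(C)c2Oc2ccc(C)cc2)c1Cl` likewise gives only a limit, < 80%. The step that the two limits leave unreadable from compound 1 to compound 2 arises from methyl in place of bromo on an aromatic carbon. Compound 3 `Cc1nn(C)c(Oc2ccc(Br)cc2)c1/C=N\OCc1c(Cl)c(-c2ccc(Cl)cc2)nn1C` gives 80%; the difference between its core and the core of compound 1 is not broken down here. Compound 4 `Cc1ccc(Oc2c(/C=N\OCc3c(Cl)c(-c4ccc(Cl)cc4)nn3C)c(C)nn2C)cc1` carries the same change that turns compound 1 into compound 2: methyl in place of bromo on an aromatic carbon. Because the limit of < 80% in this assay, at which 2 of the 3 values shown sit, leaves the earlier step unreadable, no size can be carried over from it. The step of a number 10 percentage points lower from compound 3 to compound 4 (within the scatter) is an estimate that rests only on compound 3 giving 80% and on the earlier step offering nothing readable. Compound 4 is therefore expected to give about 70%, somewhere between 45% and 85%.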

Compound 4, a percentage reported as inhibition, at one concentration (the size of the read-out at that concentration, not a potency): 80%
Estimate against measurement, compound 4: 10 percentage points below, and the stated range covers the measured number.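

In this assay, the swap of 4-bromophenyl to 4-methylphenyl gives no change at the digits printed from compound 3 to compound 4 (within the scatter). The same swap on the core of compound 1 cannot be read, because both of its values are limits of the assay and not numbers: the limit of < 80% in this assay, at which 2 of the 4 values shown sit. The swap can therefore be read on one core only, so this single pair does not show that it behaves alike on another core, and a reading at one concentration is not a potency.

The compounds shown leave open what other groups would do in place of the bromo, such as an amine, a carboxylic acid or a longer chain. They also leave open how the readable pair would compare at other concentrations.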